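Ester to benzyl amide on a shared core

The compounds below may be only part of what the source reports. "The series", "measured", "known", "first", "only" and "open" are said of these compounds alone.

Measured so far:
compound 1, `O=C(CC1c2ccccc2N=C(N2CCCCC2)N1c1ccccc1)NCc1ccc(NS(=O)(=O)c2ccc(F)cc2)cc1`: 1930 nM
compound 2, `CC(C)(C)OC(=O)NCCCCCNC1=Nc2ccccc2C(CC(=O)NCc2ccccc2)N1c1ccccc1`: 7740 nM
compound 3, `COC(=O)CC1c2ccccc2N=C(NCCCCCNC(=O)OC(C)(C)C)N1c1ccc(-c2ccccc2)cc1`: 3830 nM

Of the compounds shown here, three built on one shared core have been tested in a functional assay on A549 cells (Homo sapiens) for inhibition, read by sulforhodamine B assay, with a stated time of 72 h; a lower number here means a stronger inhibitor of growth, a higher number a weaker inhibitor of growth. Compound 3 stands second highest of the three numbers. Compound 1 sits closest to it, with a number that lies within the scatter of compound 3, so the two cannot be told apart. Compound 2 lies furthest away, with a higher number that is beyond the scatter, so compound 2 is the weaker growth inhibitor of that pair.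

Compound 4, `CC(C)(C)OC(=O)NCCCCCNC1=Nc2ccccc2C(CC(=O)NCc2ccccc2)N1c1ccc(-c2ccccc2)cc1`, has not yet been measured. It differs from compound 3 in one place: benzylamino in place of methoxy on a carbonyl carbon. Within the data shown here, compound 2 carries the same benzylcarbamoyl group on a different version of the core, but no single step connects it to compound 3 or compound 4, so its value shows only that this group is compatible with activity in this assay.

For compound 4 the expectation is a modest change, if any, not beyond the scatter, written as a 1.0-fold higher number from compound 3 to compound 4 (0.02 log units; within the scatter). Compound 4 is therefore estimated at 4000 nM, with a range from 1500 nM to 11000 nM.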

Compound 4, concentration for 50% growth inhibition: 1830 nM
Compound 4: the middle estimate sits 2.2-fold (0.34 log units) above what was measured; the measured number falls inside the stated range.
By their numbers in this assay, from the lowest: compounds 4, 1 and 3 (each within the scatter of the next, the first and the last beyond it); then compound 2.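

In this assay, benzylamino in place of methoxy on the carbonyl carbon gives a 2.1-fold lower number from compound 3 to compound 4 (0.32 log units; beyond the scatter). Among these compounds, this is the first step read at this position, and it shows that the bigger benzylcarbamoyl group is tolerated here, with a number that goes down rather than up. The second new step, phenyl in place of hydrogen on an aromatic carbon, gives a 4.2-fold lower number from compound 2 to compound 4 (0.63 log units; beyond the scatter), so with the benzylcarbamoyl group in place, this added ring also goes with stronger growth inhibition.

The compounds shown leave open whether the benzyl ring or the amide hydrogen accounts for the first step, which a smaller methylamino group on the same carbonyl carbon could help separate, and how a carboxylic acid there would compare. What lies behind either step also stays open, as no measurement shown here bears on it.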